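The compounds below may be only part of what the source reports. "The series", "measured", "known", "first", "only" and "open" are said of these compounds alone.

Two compounds of this series have so far been run in an assay on isolated protein for inhibition of Apoptosis regulator Bcl-2 (Homo sapiens), read by fluorescence polarization; on this read-out lower numbers stand for stronger inhibition and higher numbers for weaker inhibition. Compound 1 `O=C(O)c1ccc(COc2cccc(/C=C3\SC(=S)N(c4ccc([N+](=O)[O-])cc4)C3=O)c2)cc1` returns only a limit in this assay, > 10000 nM. Compound 2 `Cc1ccc(N2C(=O)/C(=C/c3ccc(OCc4ccc(C(=O)O)cc4)cc3)SC2=S)cc1` likewise returns only a limit in this assay, > 10000 nM. Going by the values given here, compound 2 thus sits at the limit of > 10000 nM in this assay, at which 2 of the 2 values shown sit, and with both values at a limit no step between compound 1 and compound 2 can be sized; the two values show nothing beyond their shared limit. The next compound, compound 3 `O=C(O)c1ccc(COc2ccc(/C=C3\SC(=S)N(c4c(F)cccc4F)C3=O)cc2)cc1`, differs from compound 2 by 2,6-difluorophenyl in place of 4-methylphenyl on an amide-type nitrogen in a ring. Among the compounds with values here, no measured step bears on this change. Compound 2 gives only the limit > 10000 nM in this assay, so nothing here points toward a gain beyond the scatter. The step from compound 2 to compound 3 is expected to be a step that the limit leaves unreadable from compound 2 to compound 3, that is, none beyond the scatter. Compound 3 is expected to read 15000 nM in this assay, somewhere between 4000 nM and 60000 nM, most likely reported again as a limit.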

Compound 3, inhibition constant: > 10000 nM
Compound 3: no number, only a limit; the forecaster's own chance of this, stated with the estimate: 80%; the middle value does not contradict the limit.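

In this assay, going by these compounds alone, compound 3 gives only the limit > 10000 nM and compound 2 also stands at a limit, so no step between compound 2 and compound 3 can be read. The compounds shown leave open whether any change to the shared core gives a measurable inhibition constant.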